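Ring contraction at the aromatic amine of compound 2

A few compounds are considered here, and "the series" means these few. Any claim that something is new, unique, unknown or untested is made for them only; others in the source may bear on it.

Two members of the series have numbers in an ADME assay on microsomes from liver (Rattus norvegicus) for metabolic stability, using NADPH, with a stated time of 10 min; a lower number here means that less of the compound is left, a higher number that more of the compound is left. Compound 1 `CN(C[C@H]1Cc2c(cccc2N[C@H]2CC[C@H](N)CC2)CN1)[C@H]1CCCc2cccnc21` gives 75% in this assay. Among the measured compounds shown here, compound 2 `CN(C)C1CCN(c2cccc3c2C[C@H](CN(C)[C@H]2CCCc4cccnc42)NC3)CC1` gives 52.4% in this assay, and it stands lowest of the two numbers, with compound 1 as its only neighbour. For the measured compounds named here, the one measured step, a number 22.6 percentage points lower from compound 1 to compound 2 (beyond the scatter), is modest and beyond the scatter, and it came from putting 4-(dimethylamino)piperidin-1-yl in place of (4-aminocyclohexyl)amino on an aromatic carbon.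

Compound 3 `CN(C)[C@H]1CCN(c2cccc3c2C[C@H](CN(C)[C@H]2CCCc4cccnc42)NC3)C1` differs from compound 2 in one place: 3-(dimethylamino)pyrrolidin-1-yl in place of 4-(dimethylamino)piperidin-1-yl on an aromatic carbon. Both the leaving and the entering group carry dimethylamino on a saturated nitrogen-containing ring, and the exchange is a ring contraction from six to five members. Going by the values given here, no measured step bears on a change of this kind; the step from compound 1 to compound 2 concerns a different exchange of groups. On that basis a step in this assay from compound 2 to compound 3 of a number 2.4 percentage points lower from compound 2 to compound 3 (within the scatter) is expected, which is none beyond the scatter. Compound 3 is therefore estimated at 50%, with a range from 30% to 70%.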

Compound 3, percent of the compound remaining: 4.55%
Compound 3: the middle estimate sits 45.5 percentage points above what was measured, and the stated range ends above it.
By their numbers in this assay, from the lowest: compound 3; then compound 2; then compound 1.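

At this aromatic carbon, the saturated ring carrying the dimethylamino group proves far from interchangeable in this assay: the exchange of 4-(dimethylamino)piperidin-1-yl for 3-(dimethylamino)pyrrolidin-1-yl gives a number 47.9 percentage points lower from compound 2 to compound 3 (beyond the scatter), although both groups have the same hydrogen-bond donor and acceptor counts and no net charge. Measured against the (4-aminocyclohexyl)amino group, the same five-membered group gives a number 70.5 percentage points lower from compound 1 to compound 3 (beyond the scatter), so compound 3 sits at the bottom of the three compounds, with both of its steps beyond the scatter. No measured evidence bears on the reason for this sensitivity.

The pyrrolidine differs from the piperidine in ring size, in where the dimethylamino group sits and in carrying a defined stereocentre, and these three compounds cannot separate those differences, so the opposite stereoisomer of the 3-(dimethylamino)pyrrolidin-1-yl group remains an open comparison. Also open, going by these compounds, is whether the low number in this assay persists with a primary amine in place of the dimethylamino group on the pyrrolidine, or with a four-membered 3-(dimethylamino)azetidin-1-yl group at the same carbon.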